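A bromo substituent on the hydrazone phenyl ring

The source may report more compounds than this note shows. Statements on the series, on what has been measured and on what is new or still open speak of the compounds shown alone.

Compound 1, `COc1ccc(OC)c(/C=N/NC(=O)Nc2ccc(Oc3ccnc(-c4nncn4CCN(C)C)c3)c(F)c2)c1`: 2930 nM
Compound 2, `COc1ccc(/C=N/NC(=O)Nc2ccc(Oc3ccnc(-c4nncn4CCN(C)C)c3)c(F)c2)c(OC)c1OC`: 1790 nM
Compound 3, `CN(C)CCn1cnnc1-c1cc(Oc2ccc(NC(=O)N/N=C/c3ccccc3)cc2F)ccn1`: 1780 nM

The three measured compounds share one core and differ only in the aryl group on the carbon with a double bond to nitrogen. In a functional assay on NCI-H460 cells (Homo sapiens) for cytotoxicity, read by MTT assay, with a stated time of 72 h (a higher number here means a weaker inhibitor, a lower number a stronger inhibitor), compound 1 gives 2930 nM, compound 2 gives 1790 nM and compound 3 gives 1780 nM. Compound 3 is not separated from the other two: the steps of a 1.6-fold lower number from compound 1 to compound 3 (0.22 log units; within the scatter) and a 1.0-fold lower number from compound 2 to compound 3 (0.00 log units; within the scatter) both lie within the scatter, as does a 1.6-fold lower number from compound 1 to compound 2 (0.21 log units; within the scatter).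

Compound 4, `CN(C)CCn1cnnc1-c1cc(Oc2ccc(NC(=O)N/N=C/c3cccc(Br)c3)cc2F)ccn1`, differs from compound 3 by bromo in place of hydrogen on an aromatic carbon. Among the compounds with values here, all three measured steps vary only methoxy groups on this same ring, and none of them changes a hydrogen for a halogen, so no measured step bears directly on the change to compound 4. Since every step on this ring so far stayed within the scatter, the estimate for this assay is likewise a step of a 1.1-fold lower number from compound 3 to compound 4 (0.05 log units; within the scatter), not beyond the scatter. Compound 4 is therefore expected to give 1600 nM, with a range from 600 nM to 4500 nM.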

Compound 4, half-maximal inhibitory concentration: 520 nM
For compound 4 the middle estimate is 3.1-fold (0.49 log units) above the measured one, outside the stated range (below it).
By their numbers in this assay, from the lowest: compound 4; then compounds 3, 2 and 1 (each within the scatter of the next).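

In this assay, within the data shown here, the bromo group on the hydrazone phenyl ring produces the first change at this position that lies beyond the scatter (a 3.4-fold lower number from compound 3 to compound 4 (0.53 log units; beyond the scatter)). The 3-bromophenyl group also stands apart from both methoxy-bearing rings (a 3.4-fold lower number from compound 2 to compound 4 (0.54 log units; beyond the scatter); a 5.6-fold lower number from compound 1 to compound 4 (0.75 log units; beyond the scatter)), so compound 4 is the most potent of the four compounds shown. This position therefore does respond to substitution, even though the phenyl, 2,5-dimethoxyphenyl and 2,3,4-trimethoxyphenyl groups could not be told apart.

Going by these compounds, how a chloro group, an amine or a carboxylic acid at the same place would compare, and whether bromo elsewhere on this ring would give the same result, remains open. Nothing given here accounts for the lower number seen with the bromo group.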